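Replacing phenylsulfonyl with hydrogen in compound 3

The source may report more compounds than this note shows. Statements on the series, on what has been measured and on what is new or still open speak of the compounds shown alone.

In a functional assay on SK-MEL-28 cells (Homo sapiens) for inhibition (on this read-out lower numbers stand for stronger inhibition and higher numbers for weaker inhibition), compound 3 (`O=S(=O)(c1ccccc1)n1ccc2cc(/C=C\c3ccc4ccccc4c3)ccc21`) gives > 5000 nM, which is a limit and not a number. Compound 2 (`O=S(=O)(c1ccccc1)n1ccc2cc(/C=C/c3ccc4ccccc4c3)ccc21`) gives > 5000 nM, also a limit. Compound 1 (`COc1ccc(/C=C\c2ccc3ccccc3c2)cc1[N+](=O)[O-]`) gives > 20000 nM, again a limit. Compound 3 thus stands among values that are all limits. Compound 4 (`C(=C\c1ccc2[nH]ccc2c1)\c1ccc2ccccc2c1`) follows from compound 3 through (hydrogen in place of phenylsulfonyl on an aromatic nitrogen), with hydrogen in place of phenylsulfonyl on an aromatic nitrogen. Among the compounds with values here, the only measured step, a step that the two limits leave unreadable from compound 2 to compound 3, has no readable size and reflects (the fact that compounds 2 and 3 differ only in the configuration as drawn), so it gives no measure of this change. The expected result is a step that the limit leaves unreadable from compound 3 to compound 4, with neither its size nor its direction firmly estimated. For compound 4 the estimated value is 8000 nM, within an expected range of 1000 nM to 40000 nM.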

Compound 4, half-maximal inhibitory concentration: > 5000 nM
Compound 4 ended at the assay's limit; the forecaster's own chance of this, stated with the estimate: 60%; the middle value does not contradict the limit.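

In this assay compound 4 gives > 5000 nM, a limit and not a number, as compound 3 does, so no step can be read between compound 3 and compound 4. The compounds shown leave open what hydrogen in place of phenylsulfonyl does to inhibition, and how strongly any of them inhibits.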